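Swapping a Ring Tail on a Weak Thyroid Receptor Binder

A few compounds are considered here, and "the series" means these few. Any claim that something is new, unique, unknown or untested is made for them only; others in the source may bear on it.

Compound 1 `CC1CCN(C(=O)CCNC(=O)c2ccc(S(C)(=O)=O)c([N+](=O)[O-])c2)CC1` was tested in an assay on isolated protein for inhibition of thyroid hormone receptor beta (Homo sapiens), read by fluorescence polarization; on this read-out lower numbers stand for stronger inhibition and higher numbers for weaker inhibition. In this assay compound 1 gives > 60000 nM, which is a limit of the assay and not a number. Compound 2 `CS(=O)(=O)c1ccc(C(=O)NCCCC(=O)N2CCCCC2)cc1[N+](=O)[O-]` in this assay gives > 60000 nM, again only a limit. Going by the values given here, the one measured step, a step that the two limits leave unreadable from compound 1 to compound 2, therefore has no readable size. Compound 3 `CS(=O)(=O)c1ccc(C(=O)NCCC(=O)N2CCc3ccccc3C2)cc1[N+](=O)[O-]` differs from compound 1 by 1,2,3,4-tetrahydroisoquinolin-2-yl in place of 4-methylpiperidin-1-yl on a carbonyl carbon. Among the compounds with values here, the only evidence is the limit of > 60000 nM in this assay, at which 2 of the 2 values shown sit, which gives no direction or size to expect. Compound 3 is expected to give 60000 nM, between 10000 nM and 200000 nM. This corresponds to an expected step of a number no higher from compound 1 to compound 3 (the limit leaves the size open).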

Compound 3, half-maximal inhibitory concentration: > 60000 nM
Compound 3 was reported as a limit; the forecaster's own chance of this, stated with the estimate: 70%; the middle value lies on the limit itself.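

Going by these compounds alone, compound 1, compound 2 and compound 3 all sit at a limit of the assay, and no step among them can be read. The compounds shown leave open whether any ring tail on this core gives a measurable value.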